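A few compounds are considered here, and "the series" means these few. Any claim that something is new, unique, unknown or untested is made for them only; others in the source may bear on it.

In a functional assay on HCT-116 cells (Homo sapiens) for inhibition, read by MTT assay, with a stated time of 48 h (a higher number here means a weaker inhibitor, a lower number a stronger inhibitor), compound 1 `COc1ccc(-n2c(S)nnc2-c2cc(OC)c(OC)c(OC)c2)cc1` gives > 60000 nM, which is a limit of the assay and not a number. Compound 2 `COc1ccc(-n2c(SCc3ccc(C)cc3)nnc2-c2cc(OC)c(OC)c(OC)c2)cc1` gives a measured 33300 nM. Compound 3 `COc1ccc(-n2c(SCC(=O)c3ccc(F)cc3)nnc2-c2cc(OC)c(OC)c(OC)c2)cc1` gives > 60000 nM, again only a limit. Compound 3 therefore stands at the limit of > 60000 nM in this assay, at which 2 of the 3 values shown sit.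

Compound 4 `COc1ccc(-n2c(SCC(=O)C3CC3)nnc2-c2cc(OC)c(OC)c(OC)c2)cc1` carries cyclopropyl in place of the 4-fluorophenyl of compound 3, on a carbonyl carbon: cyclopropyl in place of 4-fluorophenyl on a carbonyl carbon. The measured steps nearest to this change are an at least 1.8-fold higher number from compound 2 to compound 3 (0.25 log units; that floor lies within the scatter), an at least 1.8-fold lower number from compound 1 to compound 2 (0.25 log units; that floor lies within the scatter) and a step that the two limits leave unreadable from compound 1 to compound 3. None of them shows a readable size beyond the scatter, and none tests this exact swap. The step expected is therefore none beyond the scatter, with an estimated a number no higher from compound 3 to compound 4 (the limit leaves the size open). Compound 4 is expected at 60000 nM, with an estimated range from 30000 nM to 120000 nM.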

Compound 4, half-maximal inhibitory concentration: > 60000 nM
Compound 4: only a limit was reported; the forecaster's own chance of this, stated with the estimate: 70%; the middle value sits exactly at the limit.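

Cyclopropyl on the carbonyl carbon leaves compound 4 at the same limit as 4-fluorophenyl does in compound 3, so neither ketone gives a readable value: the limit of > 60000 nM in this assay, at which 3 of the 4 values shown sit. The one step that can be read is an at least 1.8-fold higher number from compound 2 to compound 4 (0.25 log units; that floor lies within the scatter); the steps to compound 4 from compound 3 and from compound 1 cannot be read, as both ends are limits. Going by these compounds alone, only 4-methylbenzyl on the sulfur has given a measured number so far.

On these data alone, whether an amine or a carboxylic acid in place of cyclopropyl on the carbonyl carbon would give a measured value stays open. As far as these compounds go, how compound 3 and compound 4 truly compare also stays open.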